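The source may report more compounds than this note shows. Statements on the series, on what has been measured and on what is new or still open speak of the compounds shown alone.

Within the data shown here, in a functional assay on HCT-116 cells (Homo sapiens) for inhibition, read by CCK-8 assay, with a stated time of 48 h (on this read-out lower numbers stand for stronger inhibition and higher numbers for weaker inhibition), compound 2 `COc1ccc(CN(C(=O)CSC(=S)N2CCN(C(=O)OC(C)(C)C)CC2)c2cc(OC)c(OC)c(OC)c2)cc1` gives 620 nM, the lowest number so far. Compound 1 `CCN1CCN(C(=S)SCC(=O)N(Cc2ccc(OC)cc2)c2cc(OC)c(OC)c(OC)c2)CC1` gives 7700 nM. Compound 3 `COc1ccc(CN(C(=O)CSC(=S)N2CCN(C(=O)OC(C)(C)C)CC2)c2ccc(Br)cc2)cc1` gives > 20000 nM, which is a limit of the assay, as the limit of > 20000 nM in this assay, at which 1 of the 3 values shown sits, records. Compound 4 `COc1cc(N(Cc2ccc(Cl)cc2)C(=O)CSC(=S)N2CCN(C(=O)OC(C)(C)C)CC2)cc(OC)c1OC` differs from compound 2 at one place: chloro in place of methoxy on an aromatic carbon, with chloro in place of methoxy, turning 4-methoxybenzyl into 4-chlorobenzyl. The measured steps, a 12-fold lower number from compound 1 to compound 2 (1.09 log units; beyond the scatter) and an at least 32-fold higher number from compound 2 to compound 3 (1.50 log units; beyond the scatter), were both large, but each lies elsewhere in the structure, so neither measures this group and they bear on it only indirectly. In this assay, a moderate rise is therefore expected, with the estimated step being a 1.6-fold higher number from compound 2 to compound 4 (0.21 log units; within the scatter). Compound 4 is estimated at 1000 nM, within an expected range of 250 nM to 4000 nM.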

Compound 4, half-maximal inhibitory concentration: 8490 nM
The estimate for compound 4 lay 8.5-fold (0.93 log units) below the measured number, and the stated range ends below it.
By their numbers in this assay, from the lowest: compound 2; then compounds 1 and 4 (each within the scatter of the next). At a limit, above all of these: compound 3.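

In this assay, the first change shown on the 4-methoxybenzyl group gives a 14-fold higher number from compound 2 to compound 4 (1.14 log units; beyond the scatter), so this place, para to a large group, is not indifferent to what it carries. Earlier steps changed other parts of the structure, and this one shows that replacing methoxy with chloro here can alone produce a large change. Nothing measured here explains this step. The compounds shown leave open whether a hydroxyl, an amine or a fluoro at this place would stay near compound 2 or near compound 4.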